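Swapping a Chlorophenyl Arm for a Propyl Chain

The source may report more compounds than this note shows. Statements on the series, on what has been measured and on what is new or still open speak of the compounds shown alone.

Compound 1, `CCCOCNc1n[n+]([O-])c2cc(OC)ccc2[n+]1[O-]`, in a functional assay on PC-3 cells (Homo sapiens) for cytotoxicity, read by MTT assay, with a stated time of 72 h; on this read-out higher numbers stand for weaker inhibition and lower numbers for stronger inhibition: 6570 nM
Compound 2, `[O-][n+]1nc(NCOCc2ccc(Cl)cc2)[n+]([O-])c2ccccc21`: 5760 nM
Compound 3, `CCCCCOCNc1n[n+]([O-])c2cc(OC)ccc2[n+]1[O-]`: 3630 nM

The three numbers sit close together, and compound 2 lies between the other two, with compound 1 and compound 3 each within the usual scatter of it. Compound 4 is `CCCCOCNc1n[n+]([O-])c2ccccc2[n+]1[O-]`. Its difference from compound 2 is propyl in place of 4-chlorophenyl on a saturated chain carbon bound to an oxygen on a saturated carbon. Among the compounds with values here, only one measured step touches this arm of the molecule: a 1.8-fold lower number from compound 1 to compound 3 (0.26 log units; within the scatter), which lengthened the chain on a core carrying a methoxy group and left the number where it was, within the scatter. Within the data shown here, no measured step removes an aromatic ring from this arm, so the present change is not directly covered. Taking the small effect of chain changes in this position as the best guide, compound 4 is expected to land near compound 2, with a 1.2-fold lower number from compound 2 to compound 4 (0.06 log units; within the scatter) as the estimated step. The estimate for compound 4 is 5000 nM, expected to fall between 2500 nM and 10000 nM.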

Compound 4, half-maximal inhibitory concentration: 14700 nM
Estimate against measurement, compound 4: 2.9-fold (0.47 log units) below; measured number outside the range, above it.
By their numbers in this assay, from the lowest: compounds 3, 2 and 1 (each within the scatter of the next); then compound 4.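

In this assay, within the data shown here, putting propyl in place of 4-chlorophenyl on this saturated chain carbon gives the first step at this arm of the molecule that lies beyond the scatter (a 2.6-fold higher number from compound 2 to compound 4 (0.41 log units; beyond the scatter)). Among these compounds, the only earlier step here, a chain lengthening on the methoxy-bearing core (a 1.8-fold lower number from compound 1 to compound 3 (0.26 log units; within the scatter)), stayed within the scatter, so the arm is now seen to respond, if modestly, when an aromatic ring leaves rather than when a chain grows. Nothing measured here explains the rise in the number.

The compounds shown leave open whether the ring or the chlorine matters more, and a plain phenyl group at this place would separate the two. They also leave open whether the step would keep its size on a core carrying the methoxy group of compound 1 and compound 3.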